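This account rests on a few compounds, and the source may have more. Where it says the series, first, only, none or still open, it means among the compounds named here.

Compound 2 `COc1cc(/C=C/C(=O)c2cccc(-n3cc(-c4ccccc4)[nH]c3=O)c2)ccc1O`: 1400 nM
Compound 1 `COc1cc(/C=C/C(=O)c2cccc(-n3cc(-c4ccc(Cl)cc4)[nH]c3=O)c2)cc(OC)c1OC`: 1390 nM
Compound 3 `COc1ccc(-c2cn(-c3cccc(C(=O)/C=C/c4cc(OC)c(OC)c(OC)c4)c3)c(=O)[nH]2)cc1`: 370 nM

The read-out throughout is a functional assay on HCT-116 cells (Homo sapiens) for inhibition; on this read-out lower numbers stand for stronger inhibition of growth and higher numbers for weaker inhibition of growth. Among the three measured compounds, compound 2 carries the highest number, yet it sits level with compound 1, the two values lying within the scatter of each other; only compound 3 stands clearly apart, and the single one-place step that has been measured is a 3.8-fold lower number from compound 1 to compound 3 (0.57 log units; beyond the scatter), a methoxy in place of chloro on the outer aromatic ring.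

Compound 4 `COc1cc(/C=C/C(=O)c2cccc(-n3cc(-c4ccc(Cl)cc4)[nH]c3=O)c2)ccc1O` has not yet been measured. It differs from compound 2 in one place: chloro in place of hydrogen on an aromatic carbon. For the measured compounds named here, the one measured step concerns the same ring position but is a different exchange; it shows that swapping the group there can move the number, as a 3.8-fold lower number from compound 1 to compound 3 (0.57 log units; beyond the scatter) did, but no measured pair sets a hydrogen against a chloro at that spot. Going by the values given here, with no direct precedent, the expected step for compound 4 in this assay is no change at the digits printed from compound 2 to compound 4 (within the scatter), that is, nothing beyond the scatter. Compound 4 is therefore estimated at 1400 nM, with a range from 600 nM to 3300 nM.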

Compound 4, concentration for 50% growth inhibition: 1460 nM
Compound 4: the middle estimate sits 1.0-fold (0.02 log units) below what was measured, and the stated range covers the measured number.
By their numbers in this assay, from the lowest: compound 3; then compounds 1, 2 and 4 (each within the scatter of the next).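

In this assay the first direct test of hydrogen against chloro at this position gives a 1.0-fold higher number from compound 2 to compound 4 (0.02 log units; within the scatter) and so places the phenyl of compound 2 and the 4-chlorophenyl of compound 4 level with each other. The earlier step of a 3.8-fold lower number from compound 1 to compound 3 (0.57 log units; beyond the scatter) showed that the number can respond to the group on this aromatic carbon, but it set chloro only against methoxy, so it could not show how chloro compares with having no substituent there; this new pair shows that, in the setting of compound 2 and compound 4, adding chloro leaves the growth-inhibition number within the scatter. Nothing available here offers an explanation for this result.

The compounds shown leave open whether methoxy in place of chloro would lower the number with the rest of compound 4 kept unchanged, as it did in the step from compound 1 to compound 3. They also leave open how an amine or a carboxylic acid at this same position would read in this assay.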